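Halogen swap on the phenoxy ring: compound 3 to compound 4

The source may report more compounds than this note shows. Statements on the series, on what has been measured and on what is new or still open speak of the compounds shown alone.

Three measured compounds share one core and differ only in the ring that hangs on the oxygen. In a functional assay on HepG2 cells (Homo sapiens) for antiproliferative activity, read by MTT assay, with a stated time of 72 h (a lower number here means a stronger inhibitor, a higher number a weaker inhibitor), compound 1 `Cc1nn(C)c(Oc2cccc(F)c2)c1/C=N\CCCCCCOc1cc2oc(=O)cc(C)c2cc1Cl` gives only a limit, > 25000 nM. In this assay compound 2 `Cc1nn(C)c(Oc2ccc(F)cc2)c1/C=N\CCCCCCOc1cc2oc(=O)cc(C)c2cc1Cl` gives 12500 nM. In this assay compound 3 `Cc1nn(C)c(Oc2cccc(Cl)c2)c1/C=N\CCCCCCOc1cc2oc(=O)cc(C)c2cc1Cl` gives 6220 nM, the low end of the two plain numbers, although the gap to compound 2 lies within the scatter. Compound 4 `Cc1nn(C)c(Oc2ccc(Br)cc2)c1/C=N\CCCCCCOc1cc2oc(=O)cc(C)c2cc1Cl` is not yet measured; its change from compound 3 is 4-bromophenyl in place of 3-chlorophenyl on an oxygen on an aromatic ring. Two kinds of measured step bear on this. Moving a halogen from the 3-position to the 4-position gave an at least 2.0-fold lower number from compound 1 to compound 2 (0.30 log units; that floor lies within the scatter). Exchanging one halogen for a larger one gave an at least 4.0-fold lower number from compound 1 to compound 3 (0.60 log units; beyond the scatter). The step that mixed both changes, a 2.0-fold lower number from compound 2 to compound 3 (0.30 log units; within the scatter), was small. The new change again mixes both, so the expected step, a 1.2-fold lower number from compound 3 to compound 4 (0.09 log units; within the scatter), is one that stays within the scatter, perhaps leaning toward a lower number. Compound 4 is therefore estimated at 5000 nM, with a plausible range from 1500 nM to 16000 nM.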

Compound 4, half-maximal inhibitory concentration: 4630 nM
Compound 4: the middle estimate sits 1.1-fold (0.03 log units) above what was measured, within the range that was stated.
By their numbers in this assay, from the lowest: compounds 4, 3 and 2 (each within the scatter of the next, the first and the last beyond it). At a limit, above all of these: compound 1.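

Going by these compounds alone, with the halogen's place held fixed, bromo in place of fluoro gives a 2.7-fold lower number from compound 2 to compound 4 (0.43 log units; beyond the scatter), the first step beyond the scatter here between two plain numbers rather than against a limit. In contrast, 4-bromophenyl in place of 3-chlorophenyl gives a 1.3-fold lower number from compound 3 to compound 4 (0.13 log units; within the scatter), so these two rings cannot be ranked in this assay, even though both the halogen and its place differ. Measured against a limit, an at least 5.3-fold lower number from compound 1 to compound 4 (0.73 log units; beyond the scatter) is a floor and not a true size: the limit of > 25000 nM in this assay, at which 1 of the 4 values shown sits.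

The compounds shown do not separate the identity of the halogen from its place on the ring; 4-chlorophenyl and 3-bromophenyl would help to do that. Also open, as far as these compounds go, is how a ring without halogen, such as plain phenyl or 4-methoxyphenyl, or a longer chain would fare.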